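Replacing the dichlorophenyl arm of a cinnamate binder

The compounds below may be only part of what the source reports. "The series", "measured", "known", "first", "only" and "open" are said of these compounds alone.

Measured compounds:
- compound 1, `COC(=O)/C=C/c1cccc(N(Cc2ccc(/C=C/c3c(Cl)cccc3Cl)cc2)C(=O)C(C)C)c1`: 195 nM
- compound 2, `COC(=O)/C=C/c1cccc(N(Cc2ccc(/C=C/c3cc(C(F)(F)F)cc(C(F)(F)F)c3)cc2)C(=O)C2CCCCC2)c1`: 1470 nM
- compound 3, `COC(=O)/C=C/c1cccc(N(Cc2ccc(/C=C/c3c(C)cc(C)cc3C)cc2)C(=O)NC(C)C)c1`: 431 nM

Of the compounds shown here, three sharing the same cinnamate core have been tested in an assay on isolated protein with Bile acid receptor (Homo sapiens) as the target; a higher number here means that more compound is needed for the effect, a lower number that less compound is needed. Compound 1 gives 195 nM, the lowest of the three numbers. Compound 3 gives 431 nM, and compound 2 gives 1470 nM; both of these gaps to compound 1 lie beyond the usual scatter, so compound 1 is the most potent of the three. Among the measured compounds shown here, these three compounds differ in more than one place, so no single step between them can be read.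

Compound 4, `COC(=O)/C=C/c1cccc(N(Cc2ccc(/C=C/c3cccc(F)c3)cc2)C(=O)C(C)C)c1`, has not yet been measured. It departs from compound 1 by one change: 3-fluorophenyl in place of 2,6-dichlorophenyl on a double-bonded chain carbon bound to a double-bonded chain carbon. The two ring substituents that leave are both chlorine; the single one that enters is fluorine.

For the measured compounds named here, no measured pair isolates this change. What is known is that the other two aryl arms, in compound 2 and compound 3, sit beside higher numbers than compound 1 in this assay. On that basis the step from compound 1 to compound 4 is expected to be an increase of about a 7.7-fold higher number from compound 1 to compound 4 (0.89 log units; beyond the scatter). Compound 4 is therefore estimated at 1500 nM, with a likely range from 400 nM to 6000 nM.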

Compound 4, half-maximal effective concentration: 71 nM
Compound 4: the middle estimate sits 21-fold (1.32 log units) above what was measured; measured number below the stated range.
By their numbers in this assay, from the lowest: compound 4; then compound 1; then compound 3; then compound 2.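

Read in this assay, the exchange of 2,6-dichlorophenyl for 3-fluorophenyl on a double-bonded chain carbon bound to a double-bonded chain carbon gives a 2.7-fold lower number from compound 1 to compound 4 (0.44 log units; beyond the scatter), and it is the first step at this position that can be read on its own. It shows that the two chlorine atoms of compound 1 are not needed for a low number in this series, since the arm with a single fluorine and one heavy atom fewer goes further down, with compound 4 at 71 nM and the rest of the structure unchanged. Nothing available gives a reason for this drop.

The step changes the number of substituents, their element and their place on the ring all at once, so a plain phenyl ring with no substituent, or one carrying a single chlorine, would be needed to tell these apart. The compounds shown also leave open whether the lower number holds with the cyclohexanecarbonyl group of compound 2 or the isopropyl urea of compound 3, and how a carboxylic acid in place of the methyl ester would read.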